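Replacing the bromobenzyl of compound 2: an expected limit

The compounds below may be only part of what the source reports. "The series", "measured", "known", "first", "only" and "open" are said of these compounds alone.

Compound 1, `Cc1ccccc1Cn1cc(COc2ccc3c(=O)ccoc3c2)nn1`, in a functional assay on SGC-7901 cells (Homo sapiens) for cytotoxicity, read by MTT assay, with a stated time of 48 h (on this read-out lower numbers stand for stronger inhibition and higher numbers for weaker inhibition), gives > 100000 nM, which is a limit of the assay rather than a number.
Compound 2, `O=c1ccoc2cc(OCc3cn(Cc4ccc(Br)cc4)nn3)ccc12`, in this assay gives > 100000 nM, again a limit and not a number.

Compound 2 therefore stands at the limit of > 100000 nM in this assay, at which 2 of the 2 values shown sit, with no measured potency to place it against anything else. The only measured step, a step that the two limits leave unreadable from compound 1 to compound 2, cannot be sized, so the shared core carrying a substituted benzyl on the triazole nitrogen has so far shown no readable response to the group on that benzyl.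

Compound 3 is `N#Cc1cccc(Cn2cc(COc3ccc4c(=O)ccoc4c3)nn2)c1`. Against compound 2 the change is 3-cyanophenyl in place of 4-bromophenyl on a saturated chain carbon bound to an aromatic nitrogen. For the measured compounds named here, no measured step bears on this change in a readable way; both measured compounds sit at the limit, so nothing suggests that compound 3 would reach a measurable value. The expected step is a step that the limit leaves unreadable from compound 2 to compound 3, meaning no change beyond the scatter is anticipated. The estimate for compound 3 in this assay is 150000 nM, ranging from 30000 nM to 600000 nM, with a limit again the most likely outcome.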

Compound 3, half-maximal inhibitory concentration: > 100000 nM
Compound 3: a limit, no number; the forecaster's own chance of this, stated with the estimate: 85%; the middle value lies beyond the limit too.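

In this assay compound 3 gives > 100000 nM, again a limit and not a number. No step among compound 1, compound 2 and compound 3 can be read, so their relative potency stays unknown: the limit of > 100000 nM in this assay, at which 3 of the 3 values shown sit.

Left open is whether any group on the benzyl of the shared core would give a measured number rather than a limit in this assay.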